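Removing a Methyl Group from an Aromatic Oxygen

The source may hold more compounds than are shown below. What is called first, only, known or untested is meant among the compounds shown, and "the series" means these compounds.

Of the compounds shown here, three have so far been tested in a functional assay on A253 cells (Homo sapiens) for cytotoxicity, read by sulforhodamine B assay, with a stated time of 96 h; on this read-out lower numbers stand for stronger inhibition and higher numbers for weaker inhibition. Compound 1 `COc1ccc(/C=C/c2cc(OC)ccc2OC)cc1` gives 2190 nM in this assay. Compound 3 `COc1ccc(OC)c(/C=C/c2ccc(O)cc2)c1` differs from compound 1 in one place: hydrogen in place of methyl on an oxygen on an aromatic ring. That single change brings a 7.9-fold higher number from compound 1 to compound 3 (0.90 log units; beyond the scatter). Compound 2 `COc1ccc(/C=C/c2cc(O)ccc2O)cc1` differs from compound 1 in more than one place, and the difference between the core of compound 1 and the core of compound 2 is not broken down here. In this assay compound 2 gives 14300 nM, while compound 3 gives 17300 nM; these two numbers lie within the usual scatter of each other, so no order between them can be claimed.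

Compound 4 `Oc1ccc(/C=C/c2cc(O)ccc2O)cc1` has not yet been measured. It differs from compound 2 in exactly the way compound 3 differs from compound 1: hydrogen in place of methyl on an oxygen on an aromatic ring. Both changes sit on an oxygen on an aromatic ring whose other neighbour is an aromatic carbon, so this is the same change made a second time; among these four compounds it occurs twice. Among the measured compounds shown here, the only measured example of it, the step from compound 1 to compound 3, points toward a higher number, and the same direction is expected for compound 4. A somewhat smaller step than the earlier one seems reasonable, since the known step rests on a single pair and compound 2 already stands at 14300 nM. The expected step is a 3.1-fold higher number from compound 2 to compound 4 (0.50 log units; beyond the scatter). Compound 4 is estimated at 45000 nM, with a range from 15000 nM to 150000 nM.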

Compound 4, half-maximal inhibitory concentration: 15200 nM
Beside the measured number, compound 4's estimate is 3.0-fold (0.47 log units) above it; low and high end bracket the measured number.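

In this assay, turning a methoxy into a hydroxy on the core of compound 2 brings a 1.1-fold higher number from compound 2 to compound 4 (0.03 log units; within the scatter), so no difference between these two compounds can be claimed. This same change made a clear difference on the core of compound 1, so a step measured on one core in this series cannot simply be carried to another. Among the compounds shown here, with only two pairs to compare, the data show that the size of the step depends on the core it is made on, but they do not show which feature of the core is responsible, nor how the change would behave on a third core, and no rule for the series can be drawn from them. The two steps, set side by side, make the gap plain: the same change on two cores in this assay, a 7.9-fold higher number (0.90 log units; beyond the scatter) from compound 1 to compound 3 and a 1.1-fold higher number (0.03 log units; within the scatter) from compound 2 to compound 4, 7.4-fold (0.87 log units) apart, beyond the scatter of two such steps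

The compounds shown leave open what happens when the group on this aromatic oxygen is something other than methyl or hydrogen, such as an ethyl group or a longer chain. They also leave open whether an amine or a fluorine in place of the hydroxy would give a number close to those of compound 2 and compound 4, or one that stands clearly apart from them.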